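Swapping Methyl for Fluoro on a Shared Core

The source may report more compounds than this note shows. Statements on the series, on what has been measured and on what is new or still open speak of the compounds shown alone.

Of the compounds shown here, three built on one shared core have been tested in a functional assay on PC-3 cells (Homo sapiens) for antiproliferative activity, read by MTT assay, with a stated time of 48 h; on this read-out higher numbers stand for weaker inhibition and lower numbers for stronger inhibition. Compound 1 `COc1ccc2nc(Nc3ccnc(Nc4ccc(S(N)(=O)=O)cc4)n3)sc2c1` gives 3030 nM in this assay. Compound 2 `NS(=O)(=O)c1ccc(Nc2ncc(F)c(Nc3nc4ccc(Cl)cc4s3)n2)cc1` carries a fluoro at the position in question and a chloro where compound 1 has a methoxy; in this assay compound 2 gives 1430 nM. For compound 3 `COc1ccc2nc(Nc3nc(Nc4ccc(S(N)(=O)=O)cc4)ncc3C)sc2c1` this assay reports only a limit, > 50000 nM, so compound 3 sits at the weak end of all the numbers shown (the limit of > 50000 nM in this assay, at which 1 of the 3 values shown sits). Going by the values given here, the single measured step that changes one place, an at least 16-fold higher number from compound 1 to compound 3 (1.21 log units; beyond the scatter), shows the number climbing steeply once a methyl is put on this carbon.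

Compound 4 `COc1ccc2nc(Nc3nc(Nc4ccc(S(N)(=O)=O)cc4)ncc3F)sc2c1` has not yet been measured. It differs from compound 3 in one place: fluoro in place of methyl on an aromatic carbon. The change sits on an aromatic carbon of a six-membered aromatic ring with 2 nitrogen, two atoms from the ring nitrogen. The measured step bears on it in reverse, since removing the methyl undoes the large rise, and the values of compound 1 and compound 2 both lie far below the limit of compound 3. Compound 4 is therefore expected to give about 2500 nM, within a range from 800 nM to 8000 nM. That expectation amounts to a step of an at least 20-fold lower number from compound 3 to compound 4 (1.30 log units; beyond the scatter).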

Compound 4, half-maximal inhibitory concentration: > 50000 nM
Compound 4 gave a limit, no number (the forecaster's own chance of this, stated with the estimate: 10%); middle value at least 20-fold (1.30 log units) away from the limit.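

In this assay, fluoro in place of hydrogen on this aromatic carbon gives an at least 16-fold higher number from compound 1 to compound 4 (1.21 log units; beyond the scatter), so on the methoxy-bearing core the loss is not confined to methyl. Methoxy in place of chloro, with fluoro kept on this carbon, gives an at least 34-fold higher number from compound 2 to compound 4 (1.54 log units; beyond the scatter), so fluoro here does not rule out a low number, and compound 2 goes against any general penalty for fluoro at this position. Compound 3 and compound 4 both stand at a limit, so the step between them cannot be read: the limit of > 50000 nM in this assay, at which 2 of the 4 values shown sit.

Going by these compounds, it remains open whether any group other than hydrogen on this carbon, such as an amine or a nitrile, keeps the number low on the methoxy-bearing core. On these data alone, how methyl on this carbon behaves alongside chloro also stays open.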